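From 3-nitrophenyl to 2,3-dichlorophenyl on a shared core

The source may hold more compounds than are shown below. What is called first, only, known or untested is meant among the compounds shown, and "the series" means these compounds.

Of the compounds shown here, three with the same core have been tested in a functional assay on PC-3 cells (Homo sapiens) for antiproliferative activity, read by MTT assay, with a stated time of 72 h; a higher number here means a weaker inhibitor, a lower number a stronger inhibitor. Compound 1 `O=C(N/N=C/c1ccccc1)Nc1ccc(Oc2ccnc3[nH]ccc23)c(F)c1` gives 7940 nM, compound 2 `O=C(N/N=C/c1ccc(Br)cc1)Nc1ccc(Oc2ccnc3[nH]ccc23)c(F)c1` gives 920 nM, and compound 3 `O=C(N/N=C/c1cccc([N+](=O)[O-])c1)Nc1ccc(Oc2ccnc3[nH]ccc23)c(F)c1` gives 5140 nM. The number for compound 3 lies closest to that of compound 1, and a 1.5-fold lower number from compound 1 to compound 3 (0.19 log units; within the scatter) stays within the scatter. Against compound 2 the gap is clear, with a 5.6-fold higher number from compound 2 to compound 3 (0.75 log units; beyond the scatter).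

Compound 4 `O=C(N/N=C/c1cccc(Cl)c1Cl)Nc1ccc(Oc2ccnc3[nH]ccc23)c(F)c1` brings one change: 2,3-dichlorophenyl in place of 3-nitrophenyl on a carbon with a double bond to nitrogen. In words, 2,3-dichlorophenyl stands in place of 3-nitrophenyl on a carbon with a double bond to nitrogen. Two measured steps offer guidance. Bromo in place of hydrogen on an aromatic carbon gave an 8.6-fold lower number from compound 1 to compound 2 (0.94 log units; beyond the scatter), while nitro in place of hydrogen gave a 1.5-fold lower number from compound 1 to compound 3 (0.19 log units; within the scatter). For the measured compounds named here, no chloro compound has been measured, so the bromo step is only a loose guide. A modest step to a lower number is therefore expected in this assay. The estimate amounts to a 2.6-fold lower number from compound 3 to compound 4 (0.41 log units; beyond the scatter). For compound 4 the expected value is 2000 nM, with an estimated range of 700 nM to 5500 nM.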

Compound 4, half-maximal inhibitory concentration: "not active" (no number reported)
Compound 4 has no reported number here, so the estimate cannot be set against anything.
By their numbers in this assay, from the lowest: compound 2; then compounds 3 and 1 (each within the scatter of the next).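

In this assay, for the compounds shown here, compound 4 is reported as "not active", with no number, so no step from compound 3 to compound 4 can be read. No evidence here bears on this result. The compounds shown leave open how compound 4 would compare numerically with compound 3.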